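The source may hold more compounds than are shown below. What is called first, only, known or untested is meant among the compounds shown, and "the series" means these compounds.

Of the compounds shown here, three built on one shared core have been tested in an assay on cells for inhibition of sodium- and chloride-dependent glycine transporter 1 (Homo sapiens); a lower number here means that less compound is needed, a higher number that more compound is needed for the effect. Compound 1 `COc1cc(C(F)(F)F)ccc1C(=O)NC1(c2ccccc2)CCCN(C)C1` gives 4800 nM, compound 2 `CN1CCCC(NC(=O)c2ccc(C(F)(F)F)cc2C(F)(F)F)(c2ccccc2)C1` gives 540 nM, and compound 3 `CN1CCCC(NC(=O)c2ccc(C(F)(F)F)cc2F)(c2ccccc2)C1` gives 9900 nM, the highest of the three numbers. Compound 4 `Cc1cc(C(F)(F)F)ccc1C(=O)NC1(c2ccccc2)CCCN(C)C1` differs from compound 3 in one place: methyl in place of fluoro on an aromatic carbon. Going by the values given here, three measured steps concern the group at this same carbon: a 2.1-fold higher number from compound 1 to compound 3 (0.31 log units; beyond the scatter), an 8.9-fold lower number from compound 1 to compound 2 (0.95 log units; beyond the scatter), and an 18-fold higher number from compound 2 to compound 3 (1.26 log units; beyond the scatter). Changing this group has moved the number by modest to large amounts, and compound 3 with fluoro sits at the top. For compound 4 a lower number is expected, an estimated step of a 3.3-fold lower number from compound 3 to compound 4 (0.52 log units; beyond the scatter). Compound 4 is thus estimated at 3000 nM, within a range from 800 nM to 10000 nM.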

Compound 4, half-maximal effective concentration: 320 nM
For compound 4 the middle estimate is 9.4-fold (0.97 log units) above the measured one; the whole stated range lies above it.
By their numbers in this assay, from the lowest: compounds 4 and 2 (each within the scatter of the next); then compound 1; then compound 3.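

In this assay, putting methyl at this carbon gives the largest single step seen here, a 31-fold lower number from compound 3 to compound 4 (1.49 log units; beyond the scatter), although each of the two groups counts one heavy atom. Methyl also differs clearly from methoxy, a 15-fold lower number from compound 1 to compound 4 (1.18 log units; beyond the scatter), but not from trifluoromethyl, a 1.7-fold lower number from compound 2 to compound 4 (0.23 log units; within the scatter), so two groups now share the low end of the numbers. Nothing shown gives a reason for these differences. On these data alone, it remains open whether chloro, ethyl or an amine at this carbon would match methyl and trifluoromethyl.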